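Methyl added to the amide-bearing ring of compound 1

The source may report more compounds than this note shows. Statements on the series, on what has been measured and on what is new or still open speak of the compounds shown alone.

Measured compounds:
compound 1 `Cc1ccoc1C(=O)Nc1cccc(-c2nc3ncccc3o2)c1`: 2.9
compound 2 `O=C(Nc1ccc(F)c(-c2nc3ncccc3o2)c1)c1ccoc1`: 2.4
compound 3 `O=C(Nc1ccc(F)c(-c2nc3ncccc3o2)c1)c1cnco1`: 1.7

Of the compounds shown here, three sharing one core have been measured in a physicochemical assay for lipophilicity, read by HPLC, at pH 7.4; on this read-out lower numbers stand for lower lipophilicity and higher numbers for higher lipophilicity. Compound 1 gives the highest number of the three, 2.9; compound 2 is closest to it, with a number lower than compound 1 beyond the scatter, and compound 3 stands furthest, lower than compound 1 beyond the scatter as well. Going by the values given here, the only single-point step among the measured compounds is the change from furan-3-yl to 1,3-oxazol-5-yl on the carbonyl carbon, which gave a number 0.70 log units lower from compound 2 to compound 3 (beyond the scatter) in this assay.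

Compound 4 `Cc1ccc(NC(=O)c2occc2C)cc1-c1nc2ncccc2o1` is not yet measured. It differs from compound 1 by methyl in place of hydrogen on an aromatic carbon. Among the compounds with values here, no measured step covers the addition of a methyl to an aromatic carbon, so no direct precedent exists. Such an addition is generally expected to raise the number in this assay by a modest amount, somewhat beyond the scatter. The step from compound 1 is expected to be a number 0.40 log units higher from compound 1 to compound 4 (beyond the scatter). Compound 4 is therefore estimated at 3.3, with a range from 2.9 to 3.7.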

Compound 4, distribution coefficient: 3.3
Estimate against measurement, compound 4: no gap at the digits printed; the range from low to high includes it.
By their numbers in this assay, from the lowest: compound 3; then compound 2; then compound 1; then compound 4.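

In this assay the series now has a step on the six-membered aromatic ring of carbon only, where methyl in place of hydrogen on an aromatic carbon, ortho to a group of 9 heavy atoms and para to a group of 9 heavy atoms, gives a number 0.40 log units higher from compound 1 to compound 4 (beyond the scatter) in a single change. Going by these compounds alone, the only earlier step, a number 0.70 log units lower from compound 2 to compound 3 (beyond the scatter), lay on the carbonyl carbon, so the number is now seen to move beyond the scatter with a change at this ring position as well. No measurement shown accounts for the size of this step.

From the compounds shown here alone, whether an amine, a carboxylic acid or a longer chain at this position would move the number in the same direction remains open. Also open, going by these compounds, is whether the methyl step holds with furan-3-yl or 1,3-oxazol-5-yl on the carbonyl carbon.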